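A few compounds are considered here, and "the series" means these few. Any claim that something is new, unique, unknown or untested is made for them only; others in the source may bear on it.

Compound 1 `COc1cccc(OC2=C(Oc3cccc(OC)c3)C(=O)c3c(OC)ccc(OC)c3C2=O)c1` gives 1000 nM
Compound 2 `COc1cc(OC)cc(OC2=C(Cl)C(=O)c3c(OC)ccc(OC)c3C2=O)c1` gives 2000 nM
Compound 3 `COc1cc(OC)cc(OC2=C(Cl)C(=O)c3c(OC(C)=O)ccc(OC(C)=O)c3C2=O)c1` gives 1100 nM

All three numbers come from a functional assay on SCLC cells (Homo sapiens) for cytotoxicity; on this read-out higher numbers stand for weaker inhibition and lower numbers for stronger inhibition. Among them compound 2 has the highest number, yet compound 3 and compound 1 both sit within the usual scatter of it, so the three compounds cannot be told apart on these data; none can be called stronger or weaker than another.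

Compound 4 `COc1cccc(OC2=C(Cl)C(=O)c3c(OC)ccc(OC)c3C2=O)c1` has not yet been measured in this assay. It differs from compound 2 in one place: hydrogen in place of methoxy on an aromatic carbon. Going by the values given here, no pair of measured compounds differs by this same change, so there is no measured step to lean on. Compound 1, in which each aryl ether carries a single methoxy, gives 1000 nM, a number within the scatter of compound 2. On that basis the step from compound 2 to compound 4 is expected to stay within the scatter, with no clear direction, as a 1.3-fold lower number from compound 2 to compound 4 (0.12 log units; within the scatter). Compound 4 is therefore expected to give about 1500 nM in this assay, most likely between 600 nM and 4000 nM.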

Compound 4, half-maximal inhibitory concentration: 2000 nM
For compound 4 the middle estimate is 1.3-fold (0.12 log units) below the measured one; the measured number falls inside the stated range.
By their numbers in this assay, from the lowest: compounds 1, 3, 2 and 4 (each within the scatter of the next).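

In this assay, hydrogen in place of methoxy on an aromatic carbon gives no change at the digits printed from compound 2 to compound 4 (within the scatter). This is a direct measured comparison at this position, and it shows that the methoxy meta to a large group can be removed without any change these data can detect. Chloro in place of 3-methoxyphenoxy on a double-bonded ring carbon gives a 2.0-fold higher number from compound 1 to compound 4 (0.30 log units; within the scatter), so this much larger replacement also stays within the scatter, and neither single change separates the compounds on this read-out. No other measurement is available that could explain why these steps are this small.

The compounds shown leave open whether a different group on the same aromatic carbon, such as an amine or a carboxylic acid, would move the number beyond the scatter in either direction. They also leave open what a longer chain in place of the methoxy, or an amine in place of the chloro on the double-bonded ring carbon, would do in this assay.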